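The compounds below may be only part of what the source reports. "The series", "measured", "known", "first", "only" and "open" are said of these compounds alone.

Compound 1 `CSc1nc(-c2ccccc2)c(C#N)c(N2CCN(c3ccnc4cc(Cl)ccc34)CC2)n1` is measured in an ADME assay on HeLa cells (Homo sapiens) for inhibition, read by cell counting (a higher number here means a weaker inhibitor, a lower number a stronger inhibitor), where compound 1 gives > 250000 nM, which is a limit of the assay rather than a number. Compound 2 `CSc1nc(NCCCCNc2ccnc3cc(Cl)ccc23)c(C#N)c(-c2ccc([N+](=O)[O-])cc2)n1` gives 890 nM in this assay. Compound 3 `COc1ccc(-c2nc(SC)nc(NCCCCNc3ccnc4cc(Cl)ccc34)c2C#N)cc1` gives 3400 nM in this assay, the highest of the two numbers shown. For the measured compounds named here, the one measured step, a 3.8-fold higher number from compound 2 to compound 3 (0.58 log units; beyond the scatter), is a change of methoxy in place of nitro on an aromatic carbon and lies beyond the scatter. Compound 4 `CSc1nc(NCCCCNc2ccnc3cc(Cl)ccc23)c(C#N)c(-c2ccc(C)cc2)n1` has not yet been measured. It differs from compound 3 by methyl in place of methoxy on an aromatic carbon. Going by the values given here, no measured step exchanges a methoxy for a methyl, and the only step at hand, a 3.8-fold higher number from compound 2 to compound 3 (0.58 log units; beyond the scatter), concerns a different exchange on the same ring, so it offers little direct guidance; the expected step of a 1.1-fold lower number from compound 3 to compound 4 (0.05 log units; within the scatter) is therefore small and may sit within the scatter. Compound 4 is estimated at 3000 nM in this assay, with a range from 1000 nM to 9000 nM.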

Compound 4, half-maximal inhibitory concentration: 5000 nM
Beside the measured number, compound 4's estimate is 1.7-fold (0.22 log units) below it, within the range that was stated.
By their numbers in this assay, from the lowest: compound 2; then compounds 3 and 4 (each within the scatter of the next). At a limit, above all of these: compound 1.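

Putting methyl in place of methoxy on the aromatic carbon para to a large group gives a 1.5-fold higher number from compound 3 to compound 4 (0.17 log units; within the scatter) in this assay, so at this position the two groups cannot be told apart in this measurement. Methyl in place of nitro gives a 5.6-fold higher number from compound 2 to compound 4 (0.75 log units; beyond the scatter), and methoxy in place of nitro gives a 3.8-fold higher number from compound 2 to compound 3 (0.58 log units; beyond the scatter), so among these three compounds, which differ only at this position, the nitro compound stands apart with the lowest number. Nothing measured here explains why nitro separates from the other two groups.

The compounds shown leave open how an amine, a carboxylic acid or a halogen such as fluorine would read at this same position. They also leave open whether the gap seen with nitro would persist with a longer chain in the linker.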